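The source may hold more compounds than are shown below. What is called first, only, known or untested is meant among the compounds shown, and "the series" means these compounds.

Measured compounds:
compound 1, `Nc1n[nH]c2cc(-c3ccccn3)[nH]c(=O)c12`: 24%
compound 2, `Nc1n[nH]c2cc(-c3cccs3)[nH]c(=O)c12`: 35%

In an assay on isolated protein for inhibition of ribosomal protein S6 kinase alpha-1 (Homo sapiens), read by mobility shift assay, tested at 30 uM (a higher number here means more inhibition at the concentration tested (going by the name of the read-out), a lower number less inhibition), compound 1 gives 24%. Of the two measured numbers this is the lower one: compound 2 gives 35%, and the gap between the two lies beyond the usual scatter. Among the measured compounds shown here, only these two compounds have been measured, and no pair of them differs in a single place, so how one change alters the read-out has not yet been seen.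

Compound 3, `Cn1nc(N)c2c(=O)[nH]c(-c3ccccn3)cc21`, has not yet been measured. It differs from compound 1 in one place: methyl in place of hydrogen on an aromatic nitrogen. For the measured compounds named here, nothing measured so far shows how this change acts in this assay, so the step is expected to be small, in either direction or none beyond the scatter. For compound 3 the estimate in this assay is 18%, ranging from 0% to 40%. The step expected here, a number 6 percentage points lower from compound 1 to compound 3 (within the scatter), stays within the scatter.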

Compound 3, a percentage reported as inhibition, at one concentration (the size of the read-out at that concentration, not a potency): 9%
Compound 3: the middle estimate sits 9 percentage points above what was measured; the measured number falls inside the stated range.
By their numbers in this assay, from the lowest: compound 3; then compound 1; then compound 2.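

Read in this assay the result comes out a number 15 percentage points lower from compound 1 to compound 3 (beyond the scatter) when methyl takes the place of hydrogen on an aromatic nitrogen, and this is the first single change that can be followed in this series. It shows that this nitrogen of the five-membered aromatic ring is not a place where change goes unnoticed: a group of just one carbon, with no ring and no net charge, is enough to take the inhibition at the tested concentration beyond the usual scatter. Nothing at hand explains why the number falls.

Still open, as far as these compounds go, is whether a longer chain such as ethyl or propyl on this nitrogen would lower the number further, or whether a group such as a hydroxyethyl chain or an amine-bearing chain would behave differently. Also open, from the compounds shown here alone, is whether methyl at this place would produce a similar step in compound 2, which carries a different ring on the shared core.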